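A few compounds are considered here, and "the series" means these few. Any claim that something is new, unique, unknown or untested is made for them only; others in the source may bear on it.

Measured half-lives in an ADME assay on microsomes from liver (Rattus norvegicus) for metabolic stability, read by LC-MS, using NADPH, at 37 degrees C; a higher number here means that the compound lasts longer, a lower number that the compound disappears faster:
- compound 1 `Cc1cc(C)c(-c2nc(CN3CCC(C(=O)NCCCN4C[C@H](C)C[C@H](C)C4)CC3)c(C)o2)c(C)c1`: > 0.5 h (a limit)
- compound 2 `Cc1oc(-c2ccccc2Cl)nc1CN1CCC(C(=O)NCCCN2C[C@H](C)C[C@H](C)C2)CC1`: 0.25 h (a number)
- compound 3 `Cc1oc(-c2ccc(Cl)cc2)nc1CN1CCC(C(=O)NCCCN2C[C@H](C)C[C@H](C)C2)CC1`: > 0.5 h (a limit)

Compound 3 stands at the limit of > 0.5 h in this assay, at which 2 of the 3 values shown sit, which is a limit of the assay and not a number. Its true half-life is therefore not known.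

Compound 4 `Cc1oc(-c2ccc(F)cc2)nc1CN1CCC(C(=O)NCCCN2C[C@H](C)C[C@H](C)C2)CC1` has fluoro in place of chloro on an aromatic carbon, para to a large group, so 4-chlorophenyl becomes 4-fluorophenyl: fluoro in place of chloro on an aromatic carbon. Three measured steps change the same aromatic group. The first is an at least 2.0-fold lower number from compound 1 to compound 2 (0.30 log units; that floor lies within the scatter). The second is an at least 2.0-fold higher number from compound 2 to compound 3 (0.30 log units; that floor lies within the scatter). The third is a step that the two limits leave unreadable from compound 1 to compound 3. The two readable steps are floors within the usual scatter, and the third has no readable size. None of the three swaps chloro for fluoro, so they offer only a loose guide.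

With compound 3 at > 0.5 h, which is a limit, no step beyond the scatter is expected in this assay in either direction. The assay may well report only a limit again. The estimated change is a step that the limit leaves unreadable from compound 3 to compound 4. For compound 4 the expected half-life is 0.6 h, with an estimated range from 0.3 h to 1.2 h.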

Compound 4, half-life: 0.468 h
Estimate against measurement, compound 4: 1.3-fold (0.11 log units) above; the range from low to high includes it.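

In this assay compound 4 gives a measured number, 0.468 h, and is the only compound shown with a halogen para to a large group whose half-life is known as a number rather than a limit. Against the other measured number, the result is a 1.9-fold higher number from compound 2 to compound 4 (0.27 log units; within the scatter), so 2-chlorophenyl and 4-fluorophenyl cannot be told apart in this assay, even though the halogen and its place on the ring both differ. The other two comparisons, an at least 1.0-fold lower number from compound 3 to compound 4 (0.02 log units; that floor lies within the scatter) and an at least 1.0-fold lower number from compound 1 to compound 4 (0.02 log units; that floor lies within the scatter), give only floors, and the true size of the change from chloro to fluoro stays hidden because both starting values are limits of the assay: the limit of > 0.5 h in this assay, at which 2 of the 4 values shown sit.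

From the compounds shown here alone, it remains open whether fluoro and chloro at this place truly differ, since that would need a number for compound 3 from a longer-running version of the assay. The compounds shown also leave open how a methoxy group, a nitrile or an amine at the same place on the ring would behave, and whether a phenyl ring with no substituent would last as long as these.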